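The compounds below may be only part of what the source reports. "The series", "measured", "known", "first", "only" and "open" are said of these compounds alone.

Measured so far: compound 1 `Cc1cc(Nc2cc(N3CCN(C)CC3)nc(Nc3ccc(F)cc3)n2)n[nH]1` with 357 nM; compound 2 `COc1ccc(Nc2nc(Nc3cc(C)[nH]n3)cc(N3CCN(C)CC3)n2)cc1OC` with 462 nM.

In a functional assay on K562 cells (Homo sapiens) for antiproliferative activity, read by CCK-8 assay, with a stated time of 48 h (on this read-out lower numbers stand for stronger inhibition and higher numbers for weaker inhibition), compound 2 gives 462 nM, and compound 1 lies within the scatter of it, so neither stands apart. Compound 3 `Cc1cc(Nc2cc(N3CCN(C)CC3)nc(Nc3ccc(Cl)c(F)c3)n2)n[nH]1` differs from compound 2 by 4-chloro-3-fluorophenyl in place of 3,4-dimethoxyphenyl on a nitrogen on an aromatic ring. Going by the values given here, the only measured step that bears on this exchange of the aryl group on that nitrogen is a 1.3-fold higher number from compound 1 to compound 2 (0.11 log units; within the scatter), which stayed within the scatter. The expected step is therefore a 1.2-fold lower number from compound 2 to compound 3 (0.06 log units; within the scatter), nothing beyond the scatter. The estimate for compound 3 is 400 nM, with a range from 150 nM to 1100 nM.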

Compound 3, half-maximal inhibitory concentration: 218 nM
For compound 3 the middle estimate is 1.8-fold (0.26 log units) above the measured one; measured number inside the range.
By their numbers in this assay, from the lowest: compounds 3, 1 and 2 (each within the scatter of the next, the first and the last beyond it).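

In this assay, the aryl group on this nitrogen now gives a step that clears the scatter: a 2.1-fold lower number from compound 2 to compound 3 (0.33 log units; beyond the scatter), a modest change on replacing 3,4-dimethoxyphenyl with 4-chloro-3-fluorophenyl. Replacing 4-fluorophenyl with the same group gives a 1.6-fold lower number from compound 1 to compound 3 (0.21 log units; within the scatter), which stays within the scatter, so only compound 2 and compound 3 stand apart. The data shown offer no measured explanation for this difference. On these data alone, whether a 4-chlorophenyl group on this nitrogen would match compound 3 remains open. So does the effect of a carboxylic acid or a piperidine in that place.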